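A few compounds are considered here, and "the series" means these few. Any claim that something is new, unique, unknown or untested is made for them only; others in the source may bear on it.

Working notes on the series. Compound 1 `CC/N=C(\S)CCn1nc(-c2ccccc2)ccc1=O` is the reference point here. For the measured compounds named here, in a functional assay on the whole organism (stomach) with Rattus norvegicus as the target (a higher number here means that more compound is needed for the effect, a lower number that less compound is needed), compound 1 gives 100 mg/kg, and this is the only numerical value in the set so far. Compound 2 `N=C(S)CCn1ncccc1=O` stands apart: in this assay compound 2 reaches only > 100 mg/kg, which is a limit of the assay rather than a number, so the limit of > 100 mg/kg in this assay, at which 1 of the 2 values shown sits, applies to it. Between compound 1 and compound 2 no step is counted, and their two values show only one number and one limit.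

Compound 3 `N=C(S)CCCCn1nc(-c2ccccc2)ccc1=O` has not yet been measured in this assay. Its difference from compound 1 is a group of 5 heavy atoms (3 carbon, 1 nitrogen, 1 sulfur; no ring) in place of a group of 5 heavy atoms (3 carbon, 1 nitrogen, 1 sulfur; no ring), on a saturated chain carbon, two bonds along the chain from an aromatic nitrogen; the two compounds have the same atoms, joined differently. Going by the values given here, no step between measured compounds is available to calibrate this change. The step from compound 1 to compound 3 is expected to be no change at the digits printed from compound 1 to compound 3 (within the scatter), with no direction favoured beyond the scatter. For compound 3 the expected dose is 100 mg/kg, with a range from 40 mg/kg to 300 mg/kg.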

Compound 3, dose for half-maximal effect: > 100 mg/kg
Compound 3 ended at the assay's limit; the forecaster's own chance of this, stated with the estimate: 40%; the middle value sits exactly at the limit.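

For the compounds shown here, this is the first step, and in this assay it reads a number no lower from compound 1 to compound 3 (the limit leaves the size open). The result for compound 3 is a limit of the assay and not a number. It shows that, on a saturated chain carbon, two bonds along the chain from an aromatic nitrogen, rejoining the same atoms brings no readable gain over compound 1, so the arrangement in compound 1 remains the only one here with a number: the limit of > 100 mg/kg in this assay, at which 2 of the 3 values shown sit.

Going by these compounds alone, how far compound 3 lies from compound 1 stays open, since the limit gives no size for the step. Also open is whether an amine or a carboxylic acid at this position would give a number at all, and no compound shown separates the effect of the chain from that of the group at its end.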